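The source may report more compounds than this note shows. Statements on the series, on what has been measured and on what is new or still open speak of the compounds shown alone.

Compound 1 `COc1cncc(N2CCCNCC2)c1` is a pyridine bearing a methoxy group and a seven-membered amine ring. Going by the values given here, in an assay on HEK293 cells for displacement of a labelled ligand from Neuronal acetylcholine receptor; alpha4/beta2 (Homo sapiens) (on this read-out lower numbers stand for stronger inhibition and higher numbers for weaker inhibition), compound 1 gives 1.91 nM, the higher of the two numbers measured so far. Among the compounds with values here, its only neighbour is compound 2 `COc1cc(N2CCCNCC2)cnc1Cl`, which in this assay gives 0.676 nM; the single measured step, a 2.8-fold lower number from compound 1 to compound 2 (0.45 log units; beyond the scatter), comes from adding a chloro group to the core.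

Compound 3 `NC(=O)c1cncc(N2CCCNCC2)c1` has not yet been measured. It differs from compound 1 as follows: carbamoyl in place of methoxy on an aromatic carbon. Within the data shown here, the one known step does not involve the methoxy group at all, so it gives only a loose sense of how far a single change at the core can move the number. Among the measured compounds shown here, no measured pair shows what happens when methoxy gives way to carbamoyl, so the expectation rests on that absence of precedent rather than on a direct parallel.

For compound 3 a modestly weaker result is expected, with the step of a 2.4-fold higher number from compound 1 to compound 3 (0.37 log units; beyond the scatter) as the anticipated change. Compound 3 is estimated to give 4.5 nM in this assay, expected to lie between 1.2 nM and 17 nM.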

Compound 3, half-maximal inhibitory concentration: 20 nM
Beside the measured number, compound 3's estimate is 4.4-fold (0.65 log units) below it, outside the stated range (above it).
By their numbers in this assay, from the lowest: compound 2; then compound 1; then compound 3.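

In this assay, the swap of methoxy for carbamoyl gives a 10-fold higher number from compound 1 to compound 3 (1.02 log units; beyond the scatter), so this position, two atoms from the ring nitrogen, is sensitive to the group it carries. This step is larger than the one seen on adding chloro and runs toward weaker inhibition rather than stronger, so exchanging one small group for another on the shared core can cost more than the chloro gained. Carbamoyl differs from methoxy by an extra heavy atom, a double bond and a hydrogen-bond donor, but no measurement here shows which of these differences matters or offers any reason for the loss.

Going by these compounds, with only methoxy and carbamoyl seen at this position, it remains open whether the loss is particular to carbamoyl or whether an amine, a carboxylic acid, a nitrile or a longer chain such as ethoxy would behave in the same way. Going by these compounds alone, it also remains open whether adding chloro to compound 3 would lower the number as it did for compound 1, since that step has been seen only with methoxy in place.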